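The compounds below may be only part of what the source reports. "The series", "measured", "known", "first", "only" and "open" are said of these compounds alone.

Measured so far in a functional assay on NCI-H1299 cells (Homo sapiens) for antiproliferative activity, read by XTT assay, with a stated time of 72 h; a higher number here means a weaker inhibitor, a lower number a stronger inhibitor:
compound 1 `COc1ccc(C(=O)/C=C/c2nc3ccccc3cc2-c2ccc(OC)cc2)cc1` gives 6420 nM
compound 2 `COc1ccc(-c2cc3ccccc3nc2/C=C/C(=O)c2ccc(N)cc2)cc1` gives 6510 nM
compound 3 `COc1ccc(-c2cc3ccccc3nc2/C=C/C(=O)c2ccc([N+](=O)[O-])cc2)cc1` gives 770 nM

Compound 3 stands lowest of the three: the gaps are an 8.3-fold lower number from compound 1 to compound 3 (0.92 log units; beyond the scatter) and an 8.5-fold lower number from compound 2 to compound 3 (0.93 log units; beyond the scatter), both beyond the scatter, while a 1.0-fold higher number from compound 1 to compound 2 (0.01 log units; within the scatter) lies within it. Compound 4 `COc1ccc(-c2cc3ccccc3nc2/C=C/C(=O)c2ccsc2)cc1` differs from compound 3 by thiophen-3-yl in place of 4-nitrophenyl on a carbonyl carbon. Going by the values given here, no measured step replaces the ring on the carbonyl carbon; all three only exchange one substituent on that ring, and the nitro group is the single change that set compound 3 apart. Compound 4 loses that group with the whole ring, so a higher number in this assay is expected, roughly a 5.2-fold higher number from compound 3 to compound 4 (0.72 log units; beyond the scatter). Compound 4 is estimated at 4000 nM, range 1200 nM to 13000 nM.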

Compound 4, half-maximal inhibitory concentration: 1220 nM
Compound 4: the middle estimate sits 3.3-fold (0.52 log units) above what was measured; low and high end bracket the measured number.
By their numbers in this assay, from the lowest: compounds 3 and 4 (each within the scatter of the next); then compounds 1 and 2 (each within the scatter of the next).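

In this assay, the whole ring on the carbonyl carbon can be exchanged without a step beyond the scatter (a 1.6-fold higher number from compound 3 to compound 4 (0.20 log units; within the scatter)), so a low number at this position does not require the nitro group or a six-membered ring. The same exchange set against the other two rings gives modest steps (a 5.3-fold lower number from compound 2 to compound 4 (0.73 log units; beyond the scatter); a 5.3-fold lower number from compound 1 to compound 4 (0.72 log units; beyond the scatter)). No available evidence accounts for these steps.

The compounds shown leave open how thiophen-2-yl, furan-3-yl or a saturated ring such as cyclohexyl would behave on the carbonyl carbon.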